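The compounds below may be only part of what the source reports. "The series", "measured", "known", "first", "only" and "open" are said of these compounds alone.

Measured compounds:
compound 1 `C=CCn1c(=O)/c(=C\c2cccc(Cl)c2)[nH]c(=O)/c1=C\c1ccccc1OC` — 4500 nM in a functional assay on HL-60 cells (Homo sapiens) for cytotoxicity, read by CCK-8 assay, with a stated time of 72 h; on this read-out higher numbers stand for weaker inhibition and lower numbers for stronger inhibition
compound 2 `C=CCn1c(=O)/c(=C\c2ccccc2Cl)[nH]c(=O)/c1=C\c1ccccc1OC` — 4200 nM in this assay

Among the measured compounds shown here, only two numbers stand in this assay so far, and they lie within the scatter of each other: a 1.1-fold lower number from compound 1 to compound 2 (0.03 log units; within the scatter). Compound 2 therefore cannot be separated from compound 1 on these data; it gives the lower of the two numbers, but the gap carries no meaning.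

The next compound is compound 3 `C=CCn1c(=O)/c(=C\c2ccccc2OC)[nH]c(=O)/c1=C\c1ccccc1OC`. From compound 2 it differs in one place: methoxy in place of chloro on an aromatic carbon. For the measured compounds named here, no measured step exchanges chloro for methoxy; the only step in hand, from compound 1 to compound 2, moves the chloro from one position to another and leaves the group itself unchanged, and that step was within the scatter. Going by the values given here, it offers no guide to the size or direction of a group exchange, so the expectation rests on the absence of any movement so far: no step beyond the scatter is expected for a 1.1-fold higher number from compound 2 to compound 3 (0.03 log units; within the scatter) in this assay. Compound 3 is therefore estimated at 4500 nM, with a range from 1500 nM to 14000 nM.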

Compound 3, half-maximal inhibitory concentration: 15700 nM
Beside the measured number, compound 3's estimate is 3.5-fold (0.54 log units) below it, outside the stated range (above it).
By their numbers in this assay, from the lowest: compounds 2 and 1 (each within the scatter of the next); then compound 3.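

In this assay, among the compounds shown here, this aromatic carbon, ortho to a large group, is the first place where a change shifts the number beyond the scatter: methoxy in place of chloro gives (a 3.7-fold higher number from compound 2 to compound 3 (0.57 log units; beyond the scatter)), and 2-methoxyphenyl in place of 3-chlorophenyl gives (a 3.5-fold higher number from compound 1 to compound 3 (0.54 log units; beyond the scatter)). Moving the chloro had produced no separation (a 1.1-fold lower number from compound 1 to compound 2 (0.03 log units; within the scatter)), so among these three compounds the identity of the group counts for more than the chloro's position, and compound 3 is the weakest of the three on this read-out. No measurement on hand bears on the reason for the change.

As far as these compounds go, whether the weaker inhibition belongs to methoxy in particular or would follow from other groups in place of chloro stays open; a methyl, a hydroxy or an amine on the same carbon would bear on that. Methoxy on the second aryl group is also tested only at this one place, so a 3-methoxyphenyl would show whether its position matters where that of the chloro did not.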